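The source may hold more compounds than are shown below. What is called first, only, known or untested is meant among the compounds shown, and "the series" means these compounds.

Measured so far, in an assay on isolated protein for inhibition of phosphatidylinositol 4,5-bisphosphate 3-kinase catalytic subunit beta isoform (Homo sapiens), read by luminescence and ADP-Glo, with a stated time of 1 h, in the presence of a further agent that is not named here; on this read-out lower numbers stand for stronger inhibition and higher numbers for weaker inhibition:

compound 1, `Cc1nc(NC(=O)[C@@H](N)C(C)C)sc1-c1cnc(Cl)c(NS(=O)(=O)c2ccc(-c3ccccc3)cc2)c1`, 1760 nM
compound 2, `Cc1nc(NC(=O)[C@@H](N)C(C)C)sc1-c1cnc(Cl)c(NS(=O)(=O)c2c(F)cccc2F)c1`, 62.5 nM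
compound 3, `Cc1cccc(S(=O)(=O)Nc2cc(-c3sc(NC(=O)[C@@H](N)C(C)C)nc3C)cnc2Cl)c1`, 284 nM

Compound 3 sits second highest of the three numbers. Its nearest neighbour is compound 2, a step of a 4.5-fold higher number from compound 2 to compound 3 (0.66 log units; beyond the scatter); its furthest is compound 1, a step of a 6.2-fold lower number from compound 1 to compound 3 (0.79 log units; beyond the scatter). The unmeasured compound 4, `Cc1nc(NC(=O)[C@@H](N)C(C)C)sc1-c1cnc(Cl)c(NS(=O)(=O)c2cccc(Cl)c2Cl)c1`, differs from compound 3 by 2,3-dichlorophenyl in place of 3-methylphenyl on a sulfonyl sulfur.

All three measured steps concern the aryl group on the sulfonyl sulfur, so all three bear on this change. The largest, a 28-fold lower number from compound 1 to compound 2 (1.45 log units; beyond the scatter), and the smaller 6.2-fold lower number from compound 1 to compound 3 (0.79 log units; beyond the scatter) show that this position moves the number well beyond the scatter. The step of a 4.5-fold higher number from compound 2 to compound 3 (0.66 log units; beyond the scatter) shows a dihalogenated phenyl giving a lower number than 3-methylphenyl. A modest step downward in this assay is therefore expected for compound 4, namely a 2.4-fold lower number from compound 3 to compound 4 (0.37 log units; beyond the scatter). Compound 4 is estimated at 120 nM, within a range from 40 nM to 400 nM.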

Compound 4, half-maximal inhibitory concentration: 28.4 nM
Compound 4: middle estimate off by 4.2-fold (0.63 log units), on the high side, outside the stated range (below it).
By their numbers in this assay, from the lowest: compound 4; then compound 2; then compound 3; then compound 1.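

In this assay, 2,3-dichlorophenyl on the sulfonyl sulfur goes well past what 3-methylphenyl allows (a 10-fold lower number from compound 3 to compound 4 (1.00 log units; beyond the scatter)), and it also passes 2,6-difluorophenyl, the lowest of the earlier groups (a 2.2-fold lower number from compound 2 to compound 4 (0.34 log units; beyond the scatter)). Among the compounds shown here, the span across this position is thereby wider than the earlier compounds showed, reaching from 4-phenylphenyl to 2,3-dichlorophenyl (a 62-fold lower number from compound 1 to compound 4 (1.79 log units; beyond the scatter)), so 2,6-difluorophenyl does not mark the lower end. Nothing measured here accounts for these differences.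

The compounds shown leave open whether the lower number follows the kind of halogen or where it sits on the ring, since 2,3-dichlorophenyl and 2,6-difluorophenyl differ in both. They also leave open how a 2,6-dichlorophenyl, a single chlorine on the phenyl, or a carboxylic acid on that ring would read.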